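From methoxy to hydroxy on compound 2

The source may hold more compounds than are shown below. What is called first, only, known or untested is meant among the compounds shown, and "the series" means these compounds.

Compound 1 `COc1c(N2C[C@H]3CCCN(Cc4cn(CCCN5C(=O)/C(=N/O)c6cc(C)ccc65)nn4)[C@H]3C2)c(F)cc2c(=O)c(C(=O)O)cn(C3CC3)c12` gives 8 ug/mL
Compound 2 `CO/N=C1/C(=O)N(CCCn2cc(CN3CCC[C@@H]4CN(c5c(F)cc6c(=O)c(C(=O)O)cn(C7CC7)c6c5OC)C[C@@H]43)nn2)c2ccc(F)cc21` gives 4 ug/mL

These two compounds were tested in an ADME assay on Vero cells (Chlorocebus sabaeus) for cytotoxicity, read by MTT assay, with a stated time of 72 h; a higher number here means that more compound is tolerated, a lower number that less compound is tolerated. There, compound 2 stands at 4 ug/mL and lies within the usual scatter of compound 1 (8 ug/mL). Compound 3 `COc1c(N2C[C@H]3CCCN(Cc4cn(CCCN5C(=O)/C(=N/O)c6cc(F)ccc65)nn4)[C@H]3C2)c(F)cc2c(=O)c(C(=O)O)cn(C3CC3)c12` has not yet been measured. It departs from compound 2 by one change (hydrogen in place of methyl on an oxygen): hydrogen in place of methyl on an oxygen, which turns methoxy to hydroxy. Among the compounds with values here, no measured pair shows this change alone, so the data offer no direct guide to its size. In this assay a small upward move is therefore expected at most, and none beyond the scatter. The expected step is a 1.5-fold higher number from compound 2 to compound 3 (0.18 log units; within the scatter) (an estimate only). For compound 3 the estimated value is 6 ug/mL (expected range 2.5 ug/mL to 15 ug/mL).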

Compound 3, half-maximal cytotoxic concentration: 2 ug/mL
Beside the measured number, compound 3's estimate is 3.0-fold (0.48 log units) above it; measured number below the stated range.
By their numbers in this assay, from the lowest: compounds 3, 2 and 1 (each within the scatter of the next, the first and the last beyond it).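

In this assay, hydrogen in place of methyl on the oxygen whose other neighbour is the double-bonded nitrogen gives a 2.0-fold lower number from compound 2 to compound 3 (0.30 log units; within the scatter), so this one pair shows no methoxy to hydroxy effect that can be told apart from the scatter. Fluoro in place of methyl on an aromatic carbon gives a 4.0-fold lower number from compound 1 to compound 3 (0.60 log units; beyond the scatter), a modest step and the first single change in this set to lie beyond the scatter, with less compound tolerated. No measurement here accounts for either step.

From the compounds shown here alone, it remains open how a longer chain or an amine on that oxygen would read in this assay. Also open, going by these compounds, is how chloro or a nitrile on that aromatic carbon would read there.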